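The source may report more compounds than this note shows. Statements on the series, on what has been measured and on what is new or still open speak of the compounds shown alone.

Compound 1 `COc1ccc(NC(=O)COC(=O)/C=C/c2cc(OC)c(OCc3ccc(Cl)c(Cl)c3)c(OC)c2)cc1` gives 97800 nM in a functional assay on BEL-7404 cells (Homo sapiens) for cytotoxicity, read by MTT assay, with a stated time of 72 h; a higher number here means a weaker inhibitor, a lower number a stronger inhibitor. Compound 2 `COc1cc(/C=C/C(=O)OCC(=O)Nc2ccc(Cl)cc2)cc(OC)c1OCc1ccc(Cl)c(Cl)c1` reaches only a limit of this assay, > 200000 nM. Compound 3 `O=C(COC(=O)/C=C/c1ccc(O)c(O)c1)Nc1ccc(Cl)cc1` likewise gives only a limit, > 200000 nM.

Compound 1 and compound 2 share one core and differ by a single change, (methoxy in place of chloro on an aromatic carbon), which gave an at least 2.0-fold lower number from compound 2 to compound 1 (0.31 log units; beyond the scatter); this step is known only as a floor because of the limit of > 200000 nM in this assay, at which 2 of the 3 values shown sit. Compound 3 is built on a different core, and the difference between the two cores is not broken down here. Compound 4 `COc1ccc(NC(=O)COC(=O)/C=C/c2ccc(O)c(O)c2)cc1` has not yet been measured in this assay. It arises from compound 3 by methoxy in place of chloro on an aromatic carbon, the same change at the same kind of place as seen between compound 2 and compound 1. From compound 3 to compound 4 the expected step is an at least 2.0-fold lower number from compound 3 to compound 4 (0.30 log units; that floor lies within the scatter), resting on compound 2 and compound 1 and their step of an at least 2.0-fold lower number from compound 2 to compound 1 (0.31 log units; beyond the scatter). For compound 4 the estimate is 100000 nM, expected between 40000 nM and 200000 nM.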

Compound 4, half-maximal inhibitory concentration: > 200000 nM
Compound 4: no number, only a limit; the forecaster's own chance of this, stated with the estimate: 45%; at least 2.0-fold (0.30 log units) between middle value and limit.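

Going by these compounds alone, no step from compound 3 to compound 4 can be read, because both give only a limit in this assay and no number: the limit of > 200000 nM in this assay, at which 3 of the 4 values shown sit. Still open, as far as these compounds go, is whether methoxy in place of chloro changes the number at all on the core of compound 3.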